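The source may hold more compounds than are shown below. What is called first, only, known or untested is meant among the compounds shown, and "the series" means these compounds.

In a functional assay on MDA-MB-231 cells (Homo sapiens) for cytotoxicity, read by MTT assay, with a stated time of 72 h (a higher number here means a weaker inhibitor, a lower number a stronger inhibitor), compound 3 (`CCCN1CCN(CCCCn2c3c(c4ccccc42)C(=O)c2c[n+]([O-])c4ccccc4c2C3=O)CC1`) gives 2980 nM, the highest number of the three measured, against compound 2 (`CCCCN1CCN(CCCCn2c3c(c4ccccc42)C(=O)c2c[n+]([O-])c4ccccc4c2C3=O)CC1`) at 900 nM and compound 1 (`CN1CCN(CCCCn2c3c(c4ccccc42)C(=O)c2c[n+]([O-])c4ccccc4c2C3=O)CC1`) at 110 nM. Compound 4 (`CN1CCN(CCCCCCn2c3c(c4ccccc42)C(=O)c2c[n+]([O-])c4ccccc4c2C3=O)CC1`) has the same atoms as compound 3, joined differently: 2-(4-methylpiperazin-1-yl)ethyl in place of 4-propylpiperazin-1-yl on a saturated chain carbon, four bonds along the chain from an aromatic nitrogen. It thus carries the 4-methylpiperazin-1-yl end of compound 1, on a longer chain. The closest evidence is the large 27-fold higher number from compound 1 to compound 3 (1.43 log units; beyond the scatter) and the modest 8.2-fold higher number from compound 1 to compound 2 (0.91 log units; beyond the scatter). The modest 3.3-fold higher number from compound 2 to compound 3 (0.52 log units; beyond the scatter) shows that compound 2 breaks any steady rise with the size of the end group. Within the data shown here, no measured step changes the chain itself, so the expectation is only a modest move to a lower number in this assay, estimated as a 6.0-fold lower number from compound 3 to compound 4 (0.78 log units; beyond the scatter). For compound 4 the expected value is 500 nM, with an estimated range of 120 nM to 2000 nM.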

Compound 4, half-maximal inhibitory concentration: 2400 nM
Compound 4: middle estimate off by 4.8-fold (0.68 log units), on the low side, outside the stated range (above it).
By their numbers in this assay, from the lowest: compound 1; then compound 2; then compounds 4 and 3 (each within the scatter of the next).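

In this assay, a 22-fold higher number from compound 1 to compound 4 (1.34 log units; beyond the scatter) gives the first view of the chain alone: with the 4-methylpiperazin-1-yl end kept, the longer chain costs about as much as the larger end groups did. Shifting the same atoms from the end group into the chain gives a 1.2-fold lower number from compound 3 to compound 4 (0.09 log units; within the scatter) and, against the 4-butylpiperazin-1-yl end, a 2.7-fold higher number from compound 2 to compound 4 (0.43 log units; beyond the scatter) for the longer chain. Nothing available gives a cause for these steps. Open, from the compounds shown here alone, is how a 5-(4-methylpiperazin-1-yl)pentyl or a shorter propyl chain would read. Also open, going by these compounds, is whether a morpholine end behaves like 4-methylpiperazin-1-yl on either chain.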